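Cyano for trifluoromethyl: a second pair in the series

The compounds below may be only part of what the source reports. "The series", "measured", "known", "first", "only" and "open" are said of these compounds alone.

Compound 1 `COC(=O)C1=C(C)N=C(C)/C(=C(/O)OC)C1c1cccc(N/C(=N/CCNC2CCN(c3ccccc3C(F)(F)F)CC2)NC#N)c1` is the reference point in an assay on SK-N-MC cells for inhibition of Neuropeptide Y receptor type 1 (Homo sapiens) (a higher number here means a weaker inhibitor, a lower number a stronger inhibitor), where compound 1 gives 14 nM. Compound 2 `COC(=O)C1=C(C)N=C(C)/C(=C(/O)OC)C1c1cccc(N/C(=N/CCNC2CCN(c3ccccc3C#N)CC2)NC#N)c1` carries cyano in place of trifluoromethyl on an aromatic carbon and in this assay compound 2 gives 3 nM, a step of a 4.7-fold lower number from compound 1 to compound 2 (0.67 log units; beyond the scatter). Compound 3 `COC(=O)C1=C(C)N=C(C)/C(=C(/O)OC)C1c1cccc(NC(=O)NCCNC2CCN(c3ccccc3C(F)(F)F)CC2)c1` differs from compound 1 in its core; the difference between the two cores is not broken down here. In this assay compound 3 gives 31 nM, the highest number of the three. Compound 4 `COC(=O)C1=C(C)N=C(C)/C(=C(/O)OC)C1c1cccc(NC(=O)NCCNC2CCN(c3ccccc3C#N)CC2)c1` is compound 3 with cyano in place of trifluoromethyl on an aromatic carbon, the same change as in the first pair, with the place described in the same words. A step of similar size is expected for compound 4, a 3.9-fold lower number from compound 3 to compound 4 (0.59 log units; beyond the scatter), kept slightly smaller since it rests on one pair. This expectation rests on the step of a 4.7-fold lower number from compound 1 to compound 2 (0.67 log units; beyond the scatter). Compound 4 is therefore estimated at 8 nM in this assay, between 3 nM and 20 nM.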

Compound 4, half-maximal inhibitory concentration: 3 nM
Compound 4: the middle estimate sits 2.7-fold (0.43 log units) above what was measured; low and high end bracket the measured number.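

In this assay, cyano in place of trifluoromethyl on an aromatic carbon also lowers the number on the core of compound 3 (a 10-fold lower number from compound 3 to compound 4 (1.01 log units; beyond the scatter)), so the direction is the same on both cores shown. This supports carrying the change between these two cores only; two pairs do not show that it holds on any other core, and they give no reason for the step. The two steps cannot be told apart in size: the same change on two cores in this assay, a 4.7-fold lower number (0.67 log units; beyond the scatter) from compound 1 to compound 2 and a 10-fold lower number (1.01 log units; beyond the scatter) from compound 3 to compound 4, 2.2-fold (0.35 log units) apart, within the scatter of two such steps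

Still open, on these data alone, is how other groups at the same place, such as chlorine, methyl or methoxy, compare with cyano and trifluoromethyl. Also open, as far as these compounds go, is whether the step survives a longer chain in place of the two-carbon link.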